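Thiophen-3-yl in place of fluoro on the shared core

This account rests on a few compounds, and the source may have more. Where it says the series, first, only, none or still open, it means among the compounds named here.

Measured so far:
compound 1, `CN1CCCN(CCn2ccc3ccc(F)cc32)CC1`, 288 nM
compound 2, `Cc1ccc2ccn(CCN3CCCN(C)CC3)c2c1`, 125 nM

In an assay on HEK293 cells for binding affinity to 5-hydroxytryptamine receptor 7 (Homo sapiens), read by radioligand binding (on this read-out lower numbers stand for stronger inhibition and higher numbers for weaker inhibition), compound 1 gives the highest of the two numbers; its nearest neighbour is compound 2, with a 2.3-fold lower number from compound 1 to compound 2 (0.36 log units; beyond the scatter). Compound 3, `CN1CCCN(CCn2ccc3ccc(-c4ccsc4)cc32)CC1`, has not been measured. It differs from compound 1 by thiophen-3-yl in place of fluoro on an aromatic carbon. Within the data shown here, the one step at this position, from fluoro to methyl, was modest, and no step to an aromatic ring at that position exists, so the expectation for compound 3 is a step of about the same small size, on the lower side, and uncertain. Compound 3 is expected to give 200 nM, in the range 60 nM to 700 nM, meaning a 1.4-fold lower number from compound 1 to compound 3 (0.16 log units; within the scatter).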

Compound 3, inhibition constant: 109 nM
Compound 3: middle estimate off by 1.8-fold (0.26 log units), on the high side; the range from low to high includes it.
By their numbers in this assay, from the lowest: compounds 3 and 2 (each within the scatter of the next); then compound 1.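

In this assay, this aromatic carbon tolerates a five-membered aromatic ring in place of fluoro, and the thiophen-3-yl gives a 2.6-fold lower number from compound 1 to compound 3 (0.42 log units; beyond the scatter). Set against methyl, the ring gives a 1.1-fold lower number from compound 2 to compound 3 (0.06 log units; within the scatter), so thiophen-3-yl and methyl cannot be told apart at this position. Nothing available accounts for either step. Still open, going by these compounds, is whether other aromatic rings, such as phenyl, pyridin-3-yl or thiophen-2-yl, behave like thiophen-3-yl. Also open, on these data alone, is how a methoxy group or an amine on this carbon would compare with methyl.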